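Swapping a reactive side group for a small ring

A few compounds are considered here, and "the series" means these few. Any claim that something is new, unique, unknown or untested is made for them only; others in the source may bear on it.

The shared core carries two trifluoromethyl groups. Compound 1 `C#Cc1cc(C(F)(F)F)cc(C(F)(F)F)c1` bears an ethynyl group on it. In an ADME assay for pharmacokinetics, read by LC-MS, in phosphate buffer, with a stated time of 72 h, at pH 7.4, tested at 250 uM (on this read-out lower numbers stand for a shorter-lived compound and higher numbers for a longer-lived compound), compound 1 gives > 50 h, which is a limit of the assay rather than a number (the limit of > 50 h in this assay, at which 1 of the 2 values shown sits). Compound 2 `O=C(CBr)c1cc(C(F)(F)F)cc(C(F)(F)F)c1` carries a (bromomethyl)carbonyl group instead. In this assay compound 2 gives < 0.017 h, again a limit rather than a number (the limit of < 0.017 h in this assay, at which 1 of the 2 values shown sits). The measured step was an at least 2900-fold lower number from compound 1 to compound 2 (3.46 log units; beyond the scatter), so compound 2 stands at the short-lived end of the two values shown.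

Compound 3 `FC(F)(F)c1cc(C2CO2)cc(C(F)(F)F)c1` differs from compound 2 in one place: oxiran-2-yl in place of (bromomethyl)carbonyl on an aromatic carbon. For the measured compounds named here, the one measured step removed the same (bromomethyl)carbonyl group in the reverse direction and was large, so a large rise in half-life is expected here as well, by about an at least 2300-fold higher number from compound 2 to compound 3 (3.37 log units; beyond the scatter). Compound 3 is therefore estimated to reach a half-life of around 40 h, somewhere between 5 h and 200 h.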

Compound 3, half-life: > 50 h
Compound 3: no number, only a limit; the forecaster's own chance of this, stated with the estimate: 40%; middle value at least 1.2-fold (0.09 log units) from the limit.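

Putting oxiran-2-yl on this aromatic carbon in place of (bromomethyl)carbonyl gives, in this assay, an at least 2900-fold higher number from compound 2 to compound 3 (3.46 log units; beyond the scatter). Compound 3 stands at a limit of the assay, not at a number: the limit of > 50 h in this assay, at which 2 of the 3 values shown sit. The short half-life of compound 2 is therefore not shared by every oxygen-bearing group at this place, and even a strained-looking three-membered non-aromatic ring with one hetero atom can sit on the shared core, meta to two trifluoromethyl groups, and reach the same limit as the ethynyl group of compound 1.

Going by these compounds, the step from compound 1 to compound 3 cannot be read, so how long either compound really lasts remains open. Also open, on these data alone, is how an amine, a carboxylic acid or a longer chain at this place would behave in this assay.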